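Swapping a Fluorophenyl Group for Bromine: What to Expect

This account rests on a few compounds, and the source may have more. Where it says the series, first, only, none or still open, it means among the compounds named here.

Going by the values given here, compound 2 `Cc1c(-c2ccc(F)cc2)cc(C(=O)NC2CCCCCC2)c(=O)n1Cc1ccc(F)cc1` is the only compound here with a numerical result: in an assay on U-937 cells for inhibition of Fatty-acid amide hydrolase 1 (Homo sapiens), read by scintillation counting, with a stated time of 15 min (on this read-out lower numbers stand for stronger inhibition and higher numbers for weaker inhibition), compound 2 gives 530 nM. Compound 1 `Cc1ccc(C(=O)NC2CCCCCC2)c(=O)n1Cc1ccc(F)cc1` carries a hydrogen where compound 2 carries a 4-fluorophenyl group. In this assay compound 1 gives only a limit of the assay, > 10000 nM. Among the compounds with values here, the single measured step, an at least 18-fold lower number from compound 1 to compound 2 (1.27 log units; beyond the scatter), shows a large gain from the 4-fluorophenyl group, though its full size stays unknown because compound 1 sits at the limit of > 10000 nM in this assay, at which 1 of the 2 values shown sits.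

Compound 3 `Cc1c(Br)cc(C(=O)NC2CCCCCC2)c(=O)n1Cc1ccc(F)cc1` is not yet measured. It differs from compound 2 in one place: bromo in place of 4-fluorophenyl on an aromatic carbon. The entering bromo group is much smaller in heavy-atom count than the leaving 4-fluorophenyl group, yet it is more than the bare hydrogen of compound 1, so compound 3 lies between the two measured compounds in structure. The step from compound 1 to compound 2 bears on this change only indirectly, as it shows the cost of losing the 4-fluorophenyl group altogether. Part of that loss is expected here. Compound 3 is estimated at 3000 nM, with a range from 800 nM to 12000 nM. That estimate means an expected step of a 5.7-fold higher number from compound 2 to compound 3 (0.75 log units; beyond the scatter), weaker than compound 2 but likely short of the limit.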

Compound 3, half-maximal inhibitory concentration: 5900 nM
The estimate for compound 3 lay 2.0-fold (0.29 log units) below the measured number; the range from low to high includes it.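

At this position, a lone bromo group does not stand in for the 4-fluorophenyl group: in this assay, the change gives an 11-fold higher number from compound 2 to compound 3 (1.05 log units; beyond the scatter). Measured against hydrogen, the same bromo group gives an at least 1.6-fold lower number from compound 1 to compound 3 (0.22 log units; that floor lies within the scatter), and because that floor lies within the scatter, it does not establish that bromo improves on hydrogen at all. Compound 1 gives only a limit of the assay rather than a number, so the true size of this last step cannot be read: the limit of > 10000 nM in this assay, at which 1 of the 3 values shown sits.

The compounds shown cannot separate the contribution of the aromatic ring from that of its fluorine, a question that a plain phenyl group or a 4-chlorophenyl group at the same position could address. They also leave open whether a small carbon group such as ethyl or cyclopropyl, placed there instead of bromo, would move the number closer to that of compound 2 or leave it nearer that of compound 3.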